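The source may report more compounds than this note shows. Statements on the series, on what has been measured and on what is new or still open speak of the compounds shown alone.

In a functional assay on MV4-11 cells (Homo sapiens) for antiproliferative activity, read by resazurin assay, with a stated time of 72 h (a lower number here means a stronger inhibitor of growth, a higher number a weaker inhibitor of growth), three compounds have been measured so far. Compound 1 (`CC(=O)N1CCN(c2ccc(Nc3nccc(-c4c[nH]c5ccccc45)n3)cc2)CC1`) gives 33 nM, compound 2 (`CC(=O)N1CCN(c2ccc(Nc3nccc(-c4c[nH]c5cccnc45)n3)cc2)CC1`) gives 420 nM, and compound 3 (`CN1CCN(c2cccc(Nc3nccc(-c4cn(C)c5ncccc45)n3)c2)CC1`) gives 24 nM. Compound 3 therefore lies within the scatter of compound 1, and both stand far from compound 2. Compound 4 (`CN1CCN(c2cccc(Nc3nccc(-c4c[nH]c5ncccc45)n3)c2)CC1`) has hydrogen in place of methyl on an aromatic nitrogen. Among the compounds with values here, no measured step makes this exact change. Within the data shown here, the one step available, a 13-fold higher number from compound 1 to compound 2 (1.10 log units; beyond the scatter), is large, but it is a different swap within the ring group. Among the measured compounds shown here, it shows only that changes to this group can matter. Compound 2 also has hydrogen on this nitrogen and gives 420 nM, but it differs from compound 3 in other places too, so it serves only as a caution. A modest rise in this assay is therefore expected, perhaps no larger than the scatter. The expected size is a 1.9-fold higher number from compound 3 to compound 4 (0.27 log units; within the scatter). For compound 4 the estimate is 45 nM, with an expected range from 14 nM to 160 nM.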

Compound 4, concentration for 50% growth inhibition: 5 nM
For compound 4 the middle estimate is 9.0-fold (0.95 log units) above the measured one; the whole stated range lies above it.
By their numbers in this assay, from the lowest: compound 4; then compounds 3 and 1 (each within the scatter of the next); then compound 2.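

In this assay, replacing the methyl on this aromatic nitrogen with hydrogen gives a 4.8-fold lower number from compound 3 to compound 4 (0.68 log units; beyond the scatter) and lies beyond the scatter. Within the data shown here, this is the first direct reading of a change at this nitrogen, and it shows that, in this pair, the methyl is not needed for strong growth inhibition and that the compound with hydrogen here gives the lower number. Nothing measured here explains why hydrogen gives the lower number.

Going by these compounds, this is a single pair, so it remains open whether the same swap would have a similar effect with other groups elsewhere on the shared core. On these data alone, it is also open how an ethyl group or a longer chain on this nitrogen would compare with hydrogen and methyl.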